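Swapping vinyl for methoxy on compound 3

This account rests on a few compounds, and the source may have more. Where it says the series, first, only, none or still open, it means among the compounds named here.

Measured in a functional assay on A549 cells (Homo sapiens) for inhibition, read by CCK-8 assay, with a stated time of 48 h; on this read-out higher numbers stand for weaker inhibition and lower numbers for stronger inhibition:
- compound 1 `COc1cc(-c2ccnc3cc(-c4ccc5c(ccn5C)c4)nn23)cc(OC)c1OC`: 15 nM
- compound 2 `COc1cc(-c2ccnc3cc(-c4ccc5cc[nH]c5c4)nn23)cc(OC)c1OC`: 170 nM
- compound 3 `C=Cc1ccc(-c2cc3nccc(-c4cc(OC)c(OC)c(OC)c4)n3n2)cc1`: 1030 nM

Compound 3 has the highest number of the three, which makes it the weakest inhibitor here. Compound 4 `COc1ccc(-c2cc3nccc(-c4cc(OC)c(OC)c(OC)c4)n3n2)cc1` carries methoxy in place of vinyl on an aromatic carbon. Among the compounds with values here, two measured steps bear on this change: a 69-fold higher number from compound 1 to compound 3 (1.84 log units; beyond the scatter) and a 6.1-fold higher number from compound 2 to compound 3 (0.78 log units; beyond the scatter). Both exchanged the whole aryl group, so they show that this part of the molecule matters. Neither tests methoxy, and the change from 4-vinylphenyl to 4-methoxyphenyl is smaller. A modest move to a lower number is therefore expected, though the direction is uncertain. The expected step is a 2.6-fold lower number from compound 3 to compound 4 (0.41 log units; beyond the scatter). For compound 4, the estimated value is 400 nM, within an expected range of 100 nM to 1600 nM.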

Compound 4, half-maximal inhibitory concentration: 376 nM
Compound 4: middle estimate off by 1.1-fold (0.03 log units), on the high side; the range from low to high includes it.
By their numbers in this assay, from the lowest: compound 1; then compound 2; then compound 4; then compound 3.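

Replacing vinyl with methoxy alone gives a 2.7-fold lower number from compound 3 to compound 4 (0.44 log units; beyond the scatter) and so shows that the number responds to the group on the phenyl ring, not only to exchanging the whole aryl group. Even so, 4-methoxyphenyl still trails both other aryl groups, with a 2.2-fold higher number from compound 2 to compound 4 (0.34 log units; beyond the scatter) against 1H-indol-6-yl and a 25-fold higher number from compound 1 to compound 4 (1.40 log units; beyond the scatter) against 1-methyl-1H-indol-5-yl. No evidence at hand gives a reason for these differences. From the compounds shown here alone, what an amine, a carboxylic acid or a longer chain on the same aromatic carbon would do remains open.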